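Chloro to trifluoromethyl step carried onto a thiosemicarbazone analogue

The compounds below may be only part of what the source reports. "The series", "measured", "known", "first", "only" and "open" are said of these compounds alone.

Compound 1 `O=C1C(=O)N(CN2CCN(c3ccnc4cc(Cl)ccc34)CC2)c2ccccc21` gives 37900 nM in a functional assay on MDA-MB-468 cells (Homo sapiens) for cytotoxicity, read by sulforhodamine B assay, with a stated time of 48 h; a lower number here means a stronger inhibitor of growth, a higher number a weaker inhibitor of growth. Compound 2 `O=C1C(=O)N(CN2CCN(c3ccnc4cc(C(F)(F)F)ccc34)CC2)c2ccccc21` gives 15300 nM in this assay; the change trifluoromethyl in place of chloro on an aromatic carbon made a step of a 2.5-fold lower number from compound 1 to compound 2 (0.39 log units; beyond the scatter). Compound 3 `NC(=S)N/N=C1/C(=O)N(CN2CCN(c3ccnc4cc(Cl)ccc34)CC2)c2cc(Cl)ccc21` gives 26500 nM in this assay; the difference between the core of compound 3 and the core of compound 1 is not broken down here, and their values lie within the scatter of each other. Compound 4 `NC(=S)N/N=C1/C(=O)N(CN2CCN(c3ccnc4cc(C(F)(F)F)ccc34)CC2)c2cc(Cl)ccc21` carries the same change, (trifluoromethyl in place of chloro on an aromatic carbon), on the core of compound 3. Because compound 1 to compound 2 moved a 2.5-fold lower number from compound 1 to compound 2 (0.39 log units; beyond the scatter), a step of a 2.4-fold lower number from compound 3 to compound 4 (0.38 log units; beyond the scatter) is expected from compound 3 to compound 4 in this assay, resting on that single precedent. Compound 4 is therefore estimated at 11000 nM in this assay, expected between 5000 nM and 25000 nM.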

Compound 4, concentration for 50% growth inhibition: 11000 nM
Compound 4: the middle estimate sits on the measured number at the digits printed, within the range that was stated.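

Trifluoromethyl in place of chloro on an aromatic carbon gave a 2.4-fold lower number from compound 3 to compound 4 (0.38 log units; beyond the scatter) in this assay, and the size of the step carried over from one core to the other: the same change on two cores in this assay, a 2.5-fold lower number (0.39 log units; beyond the scatter) from compound 1 to compound 2 and a 2.4-fold lower number (0.38 log units; beyond the scatter) from compound 3 to compound 4, 1.0-fold (0.01 log units) apart, within the scatter of two such steps

This supports transfer of the change between these two cores only, in this one assay, and two steps do not establish a rule for the whole series. The steps also give no reason for their size, and they do not show whether the change would hold on a further core.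

Still open, from the compounds shown here alone, is how other groups on the same aromatic carbon would compare, such as a nitrile, a methoxy group or an amine. Also open, going by these compounds, is whether a carboxylic acid there would keep the same direction of step.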